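The source may hold more compounds than are shown below. What is called first, only, known or untested is meant among the compounds shown, and "the series" means these compounds.

Three compounds of this series share one core and differ only in the group on the amide-type nitrogen. Compound 1 `CCc1cccc(NC(=O)c2cccc(/C=C3\CC(=O)N(c4ccccc4)C3=O)c2)c1` gives 81200 nM in an ADME assay on HCT-116 cells (Homo sapiens) for cytotoxicity, read by MTT assay, with a stated time of 72 h; a higher number here means a weaker inhibitor, a lower number a stronger inhibitor. Compound 2 `COc1ccc(NC(=O)c2cccc(/C=C3\CC(=O)N(c4ccccc4)C3=O)c2)cc1` gives > 100000 nM in this assay, which is a limit of the assay and not a number. Compound 3 `COc1ccc(OC)c(NC(=O)c2cccc(/C=C3\CC(=O)N(c4ccccc4)C3=O)c2)c1` likewise gives > 100000 nM in this assay, again a limit and not a number. Compound 3 thus stands at the ceiling of the numbers shown, namely (the limit of > 100000 nM in this assay, at which 2 of the 3 values shown sit). The steps of an at least 1.2-fold higher number from compound 1 to compound 2 (0.09 log units; that floor lies within the scatter) and an at least 1.2-fold higher number from compound 1 to compound 3 (0.09 log units; that floor lies within the scatter) are floors lying within the scatter, and a step that the two limits leave unreadable from compound 2 to compound 3 cannot be read. Compound 4 `O=C(NCC1CCCCC1)c1cccc(/C=C2\CC(=O)N(c3ccccc3)C2=O)c1`, not yet measured, differs from compound 3 by cyclohexylmethyl in place of 2,5-dimethoxyphenyl on an amide-type nitrogen. Within the data shown here, no measured step concerns a non-aromatic group at this position; the measured steps show only that the three aromatic groups gave numbers that cannot be told apart. Accordingly no step beyond the scatter is expected in this assay, and the expected step is a number no higher from compound 3 to compound 4 (the limit leaves the size open). Compound 4 is estimated at 100000 nM, between 40000 nM and 250000 nM, with a fair chance that only a limit is reported.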

Compound 4, half-maximal inhibitory concentration: > 100000 nM
Compound 4 gave a limit, no number; the forecaster's own chance of this, stated with the estimate: 60%; the middle value sits exactly at the limit.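

In this assay, cyclohexylmethyl on the amide-type nitrogen extends this position to a non-aromatic ring, and this change from 2,5-dimethoxyphenyl still yields no number that separates the compounds. Among these compounds, the steps from compound 2 and compound 3 to compound 4 cannot be read, and the only step with a floor, an at least 1.2-fold higher number from compound 1 to compound 4 (0.09 log units; that floor lies within the scatter), does not set the new group apart. Neither an aromatic nor a non-aromatic ring at this position has so far given a value clearly lower than the others, and the series now gathers at its ceiling: the limit of > 100000 nM in this assay, at which 3 of the 4 values shown sit.

As far as these compounds go, it remains open whether an aminoethyl chain or a carboxylic acid on this nitrogen would give a number clearly lower than this limit. Also open, from the compounds shown here alone, is whether a change to the shared core would do so.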